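Chloro for fluoro on the core: compound 2 to compound 3

The source may report more compounds than this note shows. Statements on the series, on what has been measured and on what is new or still open speak of the compounds shown alone.

Measured so far:
compound 1 `CC1CCN(c2c(S(=O)(=O)c3cc(F)cc(F)c3)cnc3cc(Cl)ccc23)CC1`: 94%
compound 2 `Cc1ccc(S(=O)(=O)c2cnc3ccc(F)cc3c2N2CCC(C)CC2)cc1`: 91%

In an assay on isolated protein for displacement of a labelled ligand from metabotropic glutamate receptor 5 (Homo sapiens), with a stated time of 60 min, tested at 1 uM (a lower number here means less inhibition, a higher number more inhibition at the concentration tested (going by the name of the read-out)), compound 2 gives 91%. In the same assay compound 1 gives 94%; the gap between the two is within the scatter, so they are not told apart, and the two numbers are level.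

Compound 3 `Cc1ccc(S(=O)(=O)c2cnc3ccc(Cl)cc3c2N2CCC(C)CC2)cc1` is not yet measured. It differs from compound 2 by one change: chloro in place of fluoro on an aromatic carbon.

For the measured compounds named here, no step between two measured compounds isolates this change. Compound 1 also carries a chloro on its core and gives 94%, so the step from compound 2 to compound 3 is expected to be none beyond the scatter, a number 1 percentage points higher from compound 2 to compound 3 (within the scatter). On that basis compound 3 is expected to give 92%, with a range from 82% to 98%.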

Compound 3, a percentage reported as inhibition, at one concentration (the size of the read-out at that concentration, not a potency): 95%
The estimate for compound 3 lay 3 percentage points below the measured number; the range from low to high includes it.
By their numbers in this assay, from the lowest: compounds 2, 1 and 3 (each within the scatter of the next).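

In this assay, chloro in place of fluoro on this aromatic carbon of the shared core gives a number 4 percentage points higher from compound 2 to compound 3 (within the scatter) and so cannot be told apart from no change. For the compounds shown here, this is the first pair that differs in one place, and it shows that either halogen at this position keeps the inhibition at the tested concentration without a step beyond the scatter. Nothing on hand bears on why the two halogens read alike.

From the compounds shown here alone, whether this position holds up with anything other than a halogen stays open, and a methoxy group, a nitrile or an amine on this carbon would test that. A percentage at one concentration also leaves open whether compound 2 and compound 3 differ in potency.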